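This account rests on a few compounds, and the source may have more. Where it says the series, first, only, none or still open, it means among the compounds named here.

Compound 1 `COc1ccc(-c2nc(/C=C/c3cc4ccccc4nc3OC)no2)cc1` is the reference point of the series in an ADME assay on HepG2 cells (Homo sapiens) for cytotoxicity, read by sulforhodamine B assay, with a stated time of 48 h; a lower number here means that less compound is tolerated, a higher number that more compound is tolerated. Compound 1 returns only a limit there, > 220000 nM. Compound 2 `COc1nc2ccccc2cc1/C=C/c1noc(-c2ccccc2Br)n1` also returns a limit, > 195000 nM. Compound 3 `COc1cccc(-c2nc(/C=C/c3cc4ccccc4nc3OC)no2)c1` likewise returns a limit, > 220000 nM. Since every value is a limit, the steps a step that the two limits leave unreadable from compound 1 to compound 2 and a step that the two limits leave unreadable from compound 1 to compound 3 cannot be sized, nor can a step that the two limits leave unreadable from compound 2 to compound 3; the three compounds sit at the limit of > 220000 nM in this assay, at which 2 of the 3 values shown sit, and (the limit of > 195000 nM in this assay, at which 1 of the 3 values shown sits). Compound 4 `COc1nc2ccccc2cc1/C=C/c1noc(COc2ccccc2)n1` differs from compound 1 by phenoxymethyl in place of 4-methoxyphenyl on an aromatic carbon. Going by the values given here, no measured step bears readably on this change, so no movement beyond the scatter is expected, and a further limit is the likeliest outcome. Compound 4 is therefore expected at 220000 nM, within 100000 nM to 400000 nM. The expected step is a number no higher from compound 1 to compound 4 (the limit leaves the size open).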

Compound 4, half-maximal cytotoxic concentration: > 220000 nM
Compound 4: only a limit was reported; the forecaster's own chance of this, stated with the estimate: 85%; the middle value lies on the limit itself.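

Going by these compounds alone, with compound 4 also giving only a limit in this assay, no step from compound 1, compound 2 or compound 3 to compound 4 can be read. The compounds shown leave open whether phenoxymethyl, 4-methoxyphenyl, 3-methoxyphenyl and 2-bromophenyl differ at all in cytotoxicity.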